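A new ring on the carbonyl of compound 3

The source may hold more compounds than are shown below. What is called first, only, known or untested is meant among the compounds shown, and "the series" means these compounds.

In a physicochemical assay for solubility, read by mass spectrometry, in phosphate buffer, with a stated time of 24 h, at pH 7.4 (a lower number here means a less soluble compound, a higher number a more soluble compound), compound 3 `O=C(Nc1ccc(OC(F)(F)F)cc1)NC1CCN(C(=O)C2=COCC2)CC1` stands in the middle of three numbers with 11 ug/mL as its result. Compound 1 `O=C(Nc1ccc(OC(F)(F)F)cc1)NC1CCN(C(=O)C2CCOCC2)CC1` sits higher with 91 ug/mL as its result, and compound 2 `O=C(Nc1ccc(C(F)(F)F)cc1)NC1CCN(C(=O)C2=COCC2)CC1` sits lower with 2.3 ug/mL as its result. Compound 4 `O=C(Nc1ccc(OC(F)(F)F)cc1)NC1CCN(C(=O)c2cc[nH]c2)CC1` keeps the rest of compound 3 and changes one group, on a carbonyl carbon: a group of 5 heavy atoms (4 carbon, 1 nitrogen; one five-membered aromatic ring with 1 hetero atom) in place of a group of 5 heavy atoms (4 carbon, 1 oxygen; one five-membered non-aromatic ring with 1 hetero atom), on a carbonyl carbon is the whole difference, with 1H-pyrrol-3-yl entering. The closest evidence is an 8.3-fold lower number from compound 1 to compound 3 (0.92 log units; beyond the scatter) for a change on that same carbonyl carbon. The other measured step, a 4.8-fold higher number from compound 2 to compound 3 (0.68 log units; beyond the scatter) for trifluoromethoxy in place of trifluoromethyl, lies on an aromatic carbon and bears less on this change. For the measured compounds named here, no measured compound carries 1H-pyrrol-3-yl, so the direction is uncertain. A small fall is the cautious expectation, and the estimated step is a 1.4-fold lower number from compound 3 to compound 4 (0.14 log units; within the scatter) in this assay for now. For compound 4 the estimated solubility is 8 ug/mL with an expected range from 2.5 ug/mL to 30 ug/mL in this measurement.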

Compound 4, solubility: 43 ug/mL
The estimate for compound 4 lay 5.4-fold (0.73 log units) below the measured number; measured number outside the range, above it.
By their numbers in this assay, from the lowest: compound 2; then compound 3; then compound 4; then compound 1.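

In this assay, for the compounds shown here, the carbonyl carbon now shows a rise as well as a fall: there is a 3.9-fold higher number from compound 3 to compound 4 (0.59 log units; beyond the scatter) when 1H-pyrrol-3-yl replaces the five-membered non-aromatic ring, whereas the only earlier step at this place went down. The aromatic ring does not match the saturated oxan-4-yl, though, with a 2.1-fold lower number from compound 1 to compound 4 (0.33 log units; beyond the scatter) for that swap, so the type of ring on this carbon moves the number in both directions. No measurement here explains these differences between the rings.

Still open, on these data alone, is whether the hydrogen on the pyrrole nitrogen or the aromatic ring itself goes with the rise; a furan ring, or a pyrrole with a methyl group on its nitrogen, on the same carbonyl would separate the two. As far as these compounds go, whether the step carries over to the trifluoromethyl series of compound 2 is also open.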